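A few compounds are considered here, and "the series" means these few. Any claim that something is new, unique, unknown or untested is made for them only; others in the source may bear on it.

Compound 1 `Fc1ccc(C2CC(c3ccc(Cl)s3)=NN2c2nc(-c3ccc(Cl)cc3)cs2)cc1` gives 125 ug/mL in a functional assay on A549 cells (Homo sapiens) for antiproliferative activity, read by XTT assay, with a stated time of 24 h; on this read-out lower numbers stand for stronger inhibition and higher numbers for weaker inhibition. Compound 2 `Fc1ccc(C2CC(c3ccc(Cl)s3)=NN2c2nc(-c3ccc(C(F)(F)F)cc3)cs2)cc1` reaches only the limit of the method in this assay, at > 500 ug/mL. Compound 3 `CS(=O)(=O)c1ccc(-c2csc(N3N=C(c4ccc(Cl)s4)CC3c3ccc(F)cc3)n2)cc1` also reaches only the limit in this assay, at > 500 ug/mL. Compound 3 therefore stands at the weak end of what has been measured, at the same limit as one further compound (the limit of > 500 ug/mL in this assay, at which 2 of the 3 values shown sit). The steps recorded are an at least 4.0-fold higher number from compound 1 to compound 2 (0.60 log units; beyond the scatter) and an at least 4.0-fold higher number from compound 1 to compound 3 (0.60 log units; beyond the scatter), while a step that the two limits leave unreadable from compound 2 to compound 3.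

Compound 4 `Fc1ccc(C2CC(c3ccc(Cl)s3)=NN2c2nc(-c3ccccc3)cs2)cc1` differs from compound 3 by hydrogen in place of methylsulfonyl on an aromatic carbon. Among the measured compounds shown here, no measured step removes a group from this position, but the step from compound 1 to compound 3, an at least 4.0-fold higher number from compound 1 to compound 3 (0.60 log units; beyond the scatter), shows that putting methylsulfonyl there raised the number beyond the scatter, and that step runs opposite to the present one. Compound 4 is therefore expected to fall back toward a readable number, with an at least 2.5-fold lower number from compound 3 to compound 4 (0.39 log units; beyond the scatter) as the expected step, though the limit on compound 3 leaves its size uncertain. Compound 4 is estimated at 200 ug/mL, between 60 ug/mL and 600 ug/mL.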

Compound 4, half-maximal inhibitory concentration: > 500 ug/mL
Compound 4 was reported as a limit; the forecaster's own chance of this, stated with the estimate: 35%; middle value at least 2.5-fold (0.39 log units) away from the limit.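

Compound 4 stands at a limit of this assay, > 500 ug/mL. Removing the methylsulfonyl group therefore does not bring back a readable number, and the comparison with the chloro compound gives an at least 4.0-fold higher number from compound 1 to compound 4 (0.60 log units; beyond the scatter). The earlier steps could be read as trifluoromethyl and methylsulfonyl each weakening the compound, but the unsubstituted phenyl now shows that, of the four groups shown at this place, only chloro gives a readable number, while the other three leave the compounds at the limit: the limit of > 500 ug/mL in this assay, at which 3 of the 4 values shown sit.

Going by these compounds, the steps among compound 2, compound 3 and compound 4 cannot be read, so the order of these three stays unknown. Also open, on these data alone, is whether bromo, methyl, methoxy or an amine at this place would give a readable number as chloro does.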